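The compounds below may be only part of what the source reports. "The series", "measured", "known", "first", "only" and "open" are said of these compounds alone.

Working notes on the series. Compound 1 `CNc1cccc2c1nc(-c1c(F)cccc1F)n2Cc1c(F)cccc1F` gives 27.2 uM in a toxicity assay on CCRF-CEM cells (Homo sapiens) for cytotoxicity; a lower number here means that less compound is tolerated, a higher number that more compound is tolerated. Compound 2 `CN(C)c1cccc2c1nc(-c1c(F)cccc1F)n2Cc1c(F)cccc1F` reaches only the limit of this assay, > 100 uM. The change from compound 1 to compound 2 is methyl in place of hydrogen on a nitrogen on an aromatic ring, and it made an at least 3.6-fold higher number from compound 1 to compound 2 (0.56 log units; beyond the scatter). Compound 3 `CC(=O)NCc1cccc2c1nc(-c1c(F)cccc1F)n2Cc1c(F)cccc1F` gives 20.8 uM; its core differs from that of compound 1 by acetamidomethyl in place of methylamino on an aromatic carbon, and the step is a 1.3-fold lower number from compound 1 to compound 3 (0.12 log units; within the scatter). Compound 4 `CC(=O)N(C)Cc1cccc2c1nc(-c1c(F)cccc1F)n2Cc1c(F)cccc1F` is not yet measured. It differs from compound 3 by methyl in place of hydrogen on an amide-type nitrogen, the same kind of change as that from compound 1 to compound 2, but the place is not the same: there the nitrogen sits on an aromatic ring with aromatic carbon and saturated chain carbon as other neighbours, here it is an amide-type nitrogen with carbonyl carbon and saturated chain carbon. Resting on compound 1 to compound 2, an at least 3.6-fold higher number from compound 1 to compound 2 (0.56 log units; beyond the scatter), a smaller rise, a 1.9-fold higher number from compound 3 to compound 4 (0.28 log units; within the scatter), is expected for compound 4, since the place differs. Compound 4 is estimated at 40 uM, between 15 uM and 100 uM.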

Compound 4, half-maximal toxic concentration: 20.6 uM
Estimate against measurement, compound 4: 1.9-fold (0.29 log units) above; measured number inside the range.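

In this assay, methyl on the amide-type nitrogen gives a 1.0-fold lower number from compound 3 to compound 4 (0.00 log units; within the scatter), and the other two steps to compound 4 are a 1.3-fold lower number from compound 1 to compound 4 (0.12 log units; within the scatter) and an at least 4.8-fold lower number from compound 2 to compound 4 (0.68 log units; beyond the scatter). The rise seen on the nitrogen on an aromatic ring does not carry over to the amide-type nitrogen, and the two steps differ: the same change on two cores in this assay, an at least 3.6-fold higher number (0.56 log units; beyond the scatter) from compound 1 to compound 2 and a 1.0-fold lower number (0.00 log units; within the scatter) from compound 3 to compound 4, at least 3.7-fold (0.56 log units) apart, beyond the scatter of two such steps. Going by these compounds alone, this is only one pair for each place, and one of the two steps ends at a limit of the assay, so it gives neither a rule for other cores nor a cause: the limit of > 100 uM in this assay, at which 1 of the 4 values shown sits.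

Still open, on these data alone, is whether a longer chain such as ethyl on the amide-type nitrogen would shift the number in this assay. The same question stands for a carboxylic acid in place of acetamidomethyl.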